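Series notes: dimethoxyphenyl exchange repeated on a hydroxy core

This account rests on a few compounds, and the source may have more. Where it says the series, first, only, none or still open, it means among the compounds named here.

Three compounds are measured in a functional assay on MCF7 cells (Homo sapiens) for inhibition, read by sulforhodamine B assay; on this read-out higher numbers stand for weaker inhibition of growth and lower numbers for stronger inhibition of growth. Compound 1 `Clc1cccc(-c2ccc(-c3ccc(-c4nc5ccccc5[nH]4)cc3)cc2)c1` is the reference; in this assay compound 1 gives 36300 nM. Compound 2 `COc1ccc(-c2ccc(-c3ccc(-c4nc5ccccc5[nH]4)cc3)cc2)cc1OC` carries 3,4-dimethoxyphenyl in place of 3-chlorophenyl on an aromatic carbon on the same core; in this assay compound 2 gives 7600 nM, which makes the step of a 4.8-fold lower number from compound 1 to compound 2 (0.68 log units; beyond the scatter). Compound 3 `Oc1cccc2[nH]c(-c3ccc(-c4ccc(-c5cccc(Cl)c5)cc4)cc3)nc12` keeps the 3-chlorophenyl end of compound 1 but has a changed core; in this assay compound 3 gives 3420 nM, and the step is an 11-fold lower number from compound 1 to compound 3 (1.03 log units; beyond the scatter). Compound 3 thus holds the lowest number of the three, its distance to compound 2 and to compound 1 both beyond the scatter.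

Compound 4 `COc1ccc(-c2ccc(-c3ccc(-c4nc5c(O)cccc5[nH]4)cc3)cc2)cc1OC` is not yet measured. It differs from compound 3 by 3,4-dimethoxyphenyl in place of 3-chlorophenyl on an aromatic carbon. This is the same change that separates compound 1 from compound 2, and the place is described in the same words, so it counts as the same change made on a second core. The two cores differ by hydroxy in place of hydrogen on an aromatic carbon. Whether the effect of the exchange carries over to the hydroxy core is not shown by any measured pair, so the expectation rests on one step only. A step of a 3.8-fold lower number from compound 3 to compound 4 (0.58 log units; beyond the scatter) is expected for compound 4, kept a little smaller than the measured precedent because that precedent was a 4.8-fold lower number from compound 1 to compound 2 (0.68 log units; beyond the scatter) and a second such gain on an already lower number may not come through in full. Compound 4 is therefore estimated at 900 nM, with a range from 300 nM to 2700 nM.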

Compound 4, concentration for 50% growth inhibition: 190 nM
Compound 4: the middle estimate sits 4.7-fold (0.68 log units) above what was measured, outside the stated range (below it).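

In this assay, the exchange of 3-chlorophenyl for 3,4-dimethoxyphenyl keeps its direction on the hydroxy core, but the step there is an 18-fold lower number from compound 3 to compound 4 (1.26 log units; beyond the scatter), and its size does not match the step on the core of compound 1: the same change on two cores in this assay, a 4.8-fold lower number (0.68 log units; beyond the scatter) from compound 1 to compound 2 and an 18-fold lower number (1.26 log units; beyond the scatter) from compound 3 to compound 4, 3.8-fold (0.58 log units) apart, beyond the scatter of two such steps. Read the other way, hydroxy in place of hydrogen gives a 40-fold lower number from compound 2 to compound 4 (1.60 log units; beyond the scatter) with the 3,4-dimethoxyphenyl group in place, again a larger step than with 3-chlorophenyl: the same change on two cores in this assay, an 11-fold lower number (1.03 log units; beyond the scatter) from compound 1 to compound 3 and a 40-fold lower number (1.60 log units; beyond the scatter) from compound 2 to compound 4, 3.8-fold (0.58 log units) apart, beyond the scatter of two such steps. These two comparisons draw on the same four compounds, so they form one observation: in this set the direction of the exchange carries from one core to the other and its size does not, the two changes together giving more than the step for either alone would predict, but this single set of four shows neither the reason nor whether the same holds for any other group or core.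

The compounds shown leave open whether both methoxy groups are needed for the larger step, or whether a single methoxy group would give it. They also leave open whether an amine or a carboxylic acid in place of the hydroxy would show the same enhancement, and whether the pattern extends beyond this one cell line.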